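Propanoyl for propyl: one change on a shared core

The source may hold more compounds than are shown below. What is called first, only, known or untested is meant among the compounds shown, and "the series" means these compounds.

Compound 1 `CCC(=O)c1ccc2c(c1)sc(=O)n2CCN1CCCC1`: 571 nM
Compound 2 `CCCc1ccc2c(c1)sc(=O)n2CCN1CCCCC1`: 0.6 nM
Compound 3 `CN(C)CCn1c(=O)oc2cc(C(=O)c3ccccc3)ccc21`: 365 nM

In an assay on isolated protein (Cavia porcellus) with Sigma non-opioid intracellular receptor 1 (Homo sapiens) as the target, read by radioligand binding (on this read-out higher numbers stand for weaker inhibition and lower numbers for stronger inhibition), compound 2 gives 0.6 nM, the lowest of the three numbers. Its nearest neighbour is compound 3, whose value in this assay lies far beyond the scatter, and compound 1 stands further still. No two of these compounds differ in a single place, so no step between measured compounds can be read off directly.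

Compound 4 `CCC(=O)c1ccc2c(c1)sc(=O)n2CCN1CCCCC1` is not yet measured. It is built from compound 2 by one change: propanoyl in place of propyl on an aromatic carbon. Compound 1 carries the same propanoyl group, though with a different amine, and in this assay compound 1 gives 571 nM; that value, together with the value of compound 2, suggests the propanoyl compounds sit far above compound 2. A large step upward, well beyond the scatter, is therefore expected from compound 2 to compound 4, estimated as a 130-fold higher number from compound 2 to compound 4 (2.12 log units; beyond the scatter). For compound 4 the expected value in this assay is 80 nM, with a range from 8 nM to 800 nM.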

Compound 4, inhibition constant: 47 nM
Compound 4: the middle estimate sits 1.7-fold (0.23 log units) above what was measured; the range from low to high includes it.
By their numbers in this assay, from the lowest: compound 2; then compound 4; then compounds 3 and 1 (each within the scatter of the next).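

In this assay, among the compounds shown here, propanoyl in place of propyl on an aromatic carbon gives a 78-fold higher number from compound 2 to compound 4 (1.89 log units; beyond the scatter), the first direct reading at this position, and it shows that the number responds strongly to this single change on the shared core. With the propanoyl group held in place, piperidin-1-yl in place of pyrrolidin-1-yl on the saturated chain gives a 12-fold lower number from compound 1 to compound 4 (1.08 log units; beyond the scatter), so the amine also shifts the number well beyond the scatter. Nothing available bears on what lies behind either step.

The compounds shown leave open how this aromatic carbon would respond to other groups, such as a butyl chain or a 1-hydroxypropyl group. They also leave open whether the step from propyl to propanoyl would be of similar size with pyrrolidin-1-yl as the amine.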